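A Thiophen-3-yl Replacement Weighed for Solubility

The compounds below may be only part of what the source reports. "The series", "measured", "known", "first", "only" and "open" are said of these compounds alone.

Compound 1 `Cc1cc(NCc2ccccn2)n2ncc(-c3ccc(N(C)C)cc3)c2n1`: in a physicochemical assay for solubility, read by HPLC, using the shake flask method, measured as kinetic solubility, with a stated time of 2 h, at pH 7.4 (a higher number here means a more soluble compound, a lower number a less soluble compound), compound 1 gives a limit of the assay, < 5000 nM.
Compound 2 `Cc1cc(NCc2ccccn2)n2ncc(-c3cccc(F)c3)c2n1`: in this assay compound 2 gives 5000 nM.
Compound 3 `Cc1cc(NCc2ccccn2)n2ncc(-c3ccccc3C)c2n1`: in this assay compound 3 gives a limit of the assay, < 5000 nM.

Compound 3 therefore stands at the limit, sharing it with one other value shown (the limit of < 5000 nM in this assay, at which 2 of the 3 values shown sit). The measured steps around it are a number no higher from compound 2 to compound 3 (the limit leaves the size open), a step that the two limits leave unreadable from compound 1 to compound 3 and a number no lower from compound 1 to compound 2 (the limit leaves the size open); none of these resolves into a readable size, and none touches a thiophene.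

Compound 4 `Cc1cc(NCc2ccccn2)n2ncc(-c3ccsc3)c2n1` differs from compound 3 in one place: thiophen-3-yl in place of 2-methylphenyl on an aromatic carbon. Going by the values given here, no measured step bears directly on this change, so there is no ground to expect a step beyond the scatter, and the expected step in this assay from compound 3 is a step that the limit leaves unreadable from compound 3 to compound 4. Compound 4 is accordingly estimated at 3000 nM, within a range from 1000 nM to 8000 nM, with a considerable chance that this assay again reports only a limit.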

Compound 4, solubility: 9000 nM
Compound 4: middle estimate off by 3.0-fold (0.48 log units), on the low side; measured number outside the range, above it.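

Going by these compounds alone, at this position, on an aromatic carbon of a five-membered aromatic ring with 2 nitrogen, the thiophen-3-yl group supplies the first step of readable size in this assay: a 1.8-fold higher number from compound 2 to compound 4 (0.26 log units; within the scatter). Set against the two compounds held at a limit, the same group gives an at least 1.8-fold higher number from compound 3 to compound 4 (0.25 log units; that floor lies within the scatter) and an at least 1.8-fold higher number from compound 1 to compound 4 (0.25 log units; that floor lies within the scatter), so neither step is shown to pass beyond the scatter. The full size of these two steps stays unknown because compound 1 and compound 3 each give only a limit: the limit of < 5000 nM in this assay, at which 2 of the 4 values shown sit.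

The compounds shown leave open how a furan-3-yl, a thiophen-2-yl or a pyridin-3-yl group would read at this position. Also open, going by these compounds, is whether an amine or a carboxylic acid on the thiophen-3-yl ring would carry the number beyond the scatter.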